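The source may hold more compounds than are shown below. What is called first, only, known or untested is meant among the compounds shown, and "the series" means these compounds.

Measured so far in a functional assay on PANC-1 cells (Homo sapiens) for inhibition, read by MTT assay, with a stated time of 24 h; a lower number here means a stronger inhibitor, a higher number a weaker inhibitor
- compound 1 `CC1(C)[C@H]2CC[C@]1(C)N(Cc1cn(-c3ccccc3Br)nn1)C(=O)C2` with 280 nM
- compound 2 `CC1(C)[C@H]2CC[C@]1(C)N(Cc1cn(-c3ccccc3Cl)nn1)C(=O)C2` with 270 nM

Compound 2 stands level with compound 1 within the scatter. Compound 3 `CC1(C)[C@H]2CC[C@]1(C)N(Cc1cn(-c3ccc(Br)cc3)nn1)C(=O)C2` carries 4-bromophenyl in place of 2-chlorophenyl on an aromatic nitrogen and remains unmeasured. Among the compounds with values here, the only measured step bearing on this change is the exchange of bromo for chloro (a 1.0-fold lower number from compound 1 to compound 2 (0.02 log units; within the scatter)) and it lies within the scatter. Within the data shown here, no measured compound shows what moving the halogen on the phenyl ring does, so the range stays wide. In this assay the expected step is a 1.1-fold higher number from compound 2 to compound 3 (0.05 log units; within the scatter) with no shift beyond the scatter expected in either direction. The estimate for compound 3 is 300 nM with an expected range from 120 nM to 750 nM for now.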

Compound 3, half-maximal inhibitory concentration: 200 nM
Beside the measured number, compound 3's estimate is 1.5-fold (0.18 log units) above it, within the range that was stated.
By their numbers in this assay, from the lowest: compounds 3, 2 and 1 (each within the scatter of the next).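

In this assay, within the data shown here, 4-bromophenyl in place of 2-bromophenyl on the aromatic nitrogen gives the first reading on where the halogen sits on the phenyl ring (a 1.4-fold lower number from compound 1 to compound 3 (0.15 log units; within the scatter)). 4-bromophenyl in place of 2-chlorophenyl also stays within the scatter (a 1.4-fold lower number from compound 2 to compound 3 (0.13 log units; within the scatter)), so these three halogenated phenyl groups do not separate at this position. No evidence on hand bears on this result.

Still open, as far as these compounds go, is whether an amine or a carboxylic acid on the phenyl ring would separate from these compounds. The same holds for a longer chain in place of the phenyl ring.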